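A few compounds are considered here, and "the series" means these few. Any claim that something is new, unique, unknown or untested is made for them only; others in the source may bear on it.

Working notes on the series.

Compound 1 `COc1cc2c(Oc3ccc(NC(=O)c4cn(-c5cc(C)ccc5C)cn4)cc3F)ccnc2cc1OCCCN1CCN(C)CC1` is the reference point of the first pair; in a functional assay on HT-29 cells (Homo sapiens) for cytotoxicity, read by MTT assay, with a stated time of 72 h (a higher number here means a weaker inhibitor, a lower number a stronger inhibitor), compound 1 gives 470 nM. Compound 2 `COc1cc2c(Oc3ccc(NC(=O)c4cn(-c5cc(C)ccc5C)cn4)cc3F)ccnc2cc1OCCCN1CCC(C)CC1` differs from it only by 4-methylpiperidin-1-yl in place of 4-methylpiperazin-1-yl on a saturated chain carbon, three bonds along the chain from an oxygen on an aromatic ring; in this assay compound 2 gives 2220 nM, and the measured step is a 4.7-fold higher number from compound 1 to compound 2 (0.67 log units; beyond the scatter). Compound 3 `COc1cc2c(Oc3ccc(NC(=O)/C=C/S(=O)(=O)c4ccccc4F)cc3F)ccnc2cc1OCCCN1CCN(C)CC1` sits on a second core; how the core of compound 3 differs from the core of compound 1 is not broken down here. In this assay compound 3 gives 150 nM, the lowest number of the three, with compound 1 and compound 2 both higher and beyond the scatter. Compound 4 `COc1cc2c(Oc3ccc(NC(=O)/C=C/S(=O)(=O)c4ccccc4F)cc3F)ccnc2cc1OCCCN1CCC(C)CC1` is the unmeasured partner of compound 3 and carries the change (4-methylpiperidin-1-yl in place of 4-methylpiperazin-1-yl on a saturated chain carbon, three bonds along the chain from an oxygen on an aromatic ring), the place being the same word for word as in the first pair, so it is the same change. For compound 4 the expected step is a 4.7-fold higher number from compound 3 to compound 4 (0.67 log units; beyond the scatter), set beside the measured 4.7-fold higher number from compound 1 to compound 2 (0.67 log units; beyond the scatter), because the same change in compound 1 gave a 4.7-fold higher number from compound 1 to compound 2 (0.67 log units; beyond the scatter) and nothing in the series argues for a different size on the second core. Compound 4 is therefore estimated at 700 nM, with a range from 300 nM to 1600 nM.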

Compound 4, half-maximal inhibitory concentration: 760 nM
Compound 4: the middle estimate sits 1.1-fold (0.04 log units) below what was measured, and the stated range covers the measured number.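

In this assay, 4-methylpiperidin-1-yl in place of 4-methylpiperazin-1-yl on the second core gives a 5.1-fold higher number from compound 3 to compound 4 (0.70 log units; beyond the scatter), and the step on the first core agrees with it in direction and size: the same change on two cores in this assay, a 4.7-fold higher number (0.67 log units; beyond the scatter) from compound 1 to compound 2 and a 5.1-fold higher number (0.70 log units; beyond the scatter) from compound 3 to compound 4, 1.1-fold (0.03 log units) apart, within the scatter of two such steps. In this read-out, the change therefore carries from the core of compound 1 to the core of compound 3 without a difference that the two pairs can detect. For the compounds shown here, this rests on only two pairs in a single assay, so it does not show why the step has this size, nor that it would hold on a further core or in another assay.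

The compounds shown leave open how other groups on the same chain would read on the two cores, such as a morpholine, a dimethylamino group or an unsubstituted piperidine. Also open, from the compounds shown here alone, is whether the step stays the same with a shorter or longer chain than the 3-(4-methylpiperazin-1-yl)propyl group.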